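This account rests on a few compounds, and the source may have more. Where it says the series, first, only, none or still open, it means among the compounds named here.

Going by the values given here, compound 2 `O=C(/C=C/c1cnccc1-c1cnn(C2CC2)c1)Nc1ccc(CN2CC3CC2CO3)cc1` sits at the lower end of the two numbers so far obtained in an assay on cells for inhibition of cyclin-dependent kinase 8 (Homo sapiens), with stated times of 2 h and 1 h; a higher number here means that more compound is needed for the effect, a lower number that less compound is needed. In this assay, among the compounds with values here, compound 2 gives 3.1 nM, whereas compound 1 `Cn1cc(-c2ccncc2/C=C/C(=O)Nc2ccc(CN3CC4CC3CO4)cc2)cn1` gives 19 nM; the one step measured, a 6.1-fold lower number from compound 1 to compound 2 (0.79 log units; beyond the scatter), concerns a cyclopropyl in place of methyl on an aromatic nitrogen and lies at the other end of the shared core. Compound 3 `O=C(/C=C/c1cnccc1-c1cnn(C2CC2)c1)Nc1ccc(CN2CC3CC(C2)O3)cc1` keeps that cyclopropyl and instead alters the saturated bicyclic amine: a group of 7 heavy atoms (5 carbon, 1 nitrogen, 1 oxygen; one four-membered non-aromatic ring with 1 hetero atom, one six-membered non-aromatic ring with 1 hetero atom) in place of a group of 7 heavy atoms (5 carbon, 1 nitrogen, 1 oxygen; 2 five-membered non-aromatic rings with 1 hetero atom each), on a saturated chain carbon bound to an aromatic carbon. Within the data shown here, the same atoms are present in both, joined differently, and the only group attached to the benzylic carbon changes. Among the measured compounds shown here, no measured step touches this part of the molecule, so there is nothing in the data that bears on the direction or size of the change; the step from compound 1 to compound 2 does not inform it. On that basis the step is expected to fall within the scatter, and compound 3 is estimated at 3.5 nM, with a range from 1.2 nM to 10 nM, which corresponds to an expected step of a 1.1-fold higher number from compound 2 to compound 3 (0.05 log units; within the scatter).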

Compound 3, half-maximal effective concentration in the cyclin-dependent kinase 8 assay: 5.5 nM
Compound 3: the middle estimate sits 1.6-fold (0.20 log units) below what was measured; low and high end bracket the measured number.
By their numbers in the cyclin-dependent kinase 8 assay, from the lowest: compounds 2 and 3 (each within the scatter of the next); then compound 1.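

Replacing the group with 2 five-membered non-aromatic rings by the group with one four-membered and one six-membered non-aromatic ring, on a saturated chain carbon bound to an aromatic carbon, gives in the cyclin-dependent kinase 8 assay a 1.8-fold higher number from compound 2 to compound 3 (0.25 log units; within the scatter). For this one pair, then, the same atoms joined differently at this place leave the number within the scatter, unlike the step at the other end of the shared core, which lay beyond it. In a physicochemical assay for solubility, at pH 6.8 (a higher number here means a more soluble compound, a lower number a less soluble compound), compound 2 gives > 92 ug/mL, which is a limit of the assay and not a number: the limit of > 92 ug/mL in the physicochemical assay, at which 1 of the 2 values shown sits.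

Going by these compounds, in the physicochemical assay compound 3 gives 60 ug/mL, and the pair shows an at least 1.5-fold lower number from compound 2 to compound 3 (0.18 log units; that floor lies within the scatter), so the true size of that gap remains unknown. On these data alone, whether a single-ring amine such as morpholine or piperidine, on the same saturated chain carbon, would keep the number in the cyclin-dependent kinase 8 assay remains open, as does whether an isopropyl or a tert-butyl group on the aromatic nitrogen would extend the step seen with cyclopropyl.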